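A few compounds are considered here, and "the series" means these few. Any claim that something is new, unique, unknown or untested is made for them only; others in the source may bear on it.

Of the compounds shown here, two built on a shared core have been tested in an assay on microsomes from liver for inhibition of 3-hydroxy-3-methylglutaryl-coenzyme A reductase (Rattus norvegicus); on this read-out higher numbers stand for weaker inhibition and lower numbers for stronger inhibition. Compound 1 `CC(C)c1c(C(=O)NCc2ccc(Cl)cc2)nn(-c2ccc(F)cc2)c1OC[C@@H](O)C[C@@H](O)CC(=O)O` gives 6.7 nM. Compound 2 `CC(C)c1c(C(=O)N(C)Cc2cccc(C(F)(F)F)c2)nn(-c2ccc(F)cc2)c1OC[C@@H](O)C[C@@H](O)CC(=O)O` gives 31 nM, the higher of the two numbers, and its gap to compound 1 lies beyond the scatter. Compound 3 `CC(C)c1c(C(=O)N(C)Cc2ccc(F)c(F)c2)nn(-c2ccc(F)cc2)c1OC[C@@H](O)C[C@@H](O)CC(=O)O` differs from compound 2 in one place: 3,4-difluorophenyl in place of 3-(trifluoromethyl)phenyl on a saturated chain carbon bound to an amide-type nitrogen. Among the compounds with values here, no measured pair shows this exact change, so the step of a 1.2-fold lower number from compound 2 to compound 3 (0.09 log units; within the scatter) is expected to be small, probably not beyond the scatter, leaning slightly toward a lower number. Compound 3 is therefore estimated at 25 nM, with a range from 10 nM to 60 nM.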

Compound 3, half-maximal inhibitory concentration: 5.7 nM
Compound 3: the middle estimate sits 4.4-fold (0.64 log units) above what was measured; measured number outside the range, below it.
By their numbers in this assay, from the lowest: compounds 3 and 1 (each within the scatter of the next); then compound 2.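

In this assay, 3,4-difluorophenyl in place of 3-(trifluoromethyl)phenyl gives a 5.4-fold lower number from compound 2 to compound 3 (0.74 log units; beyond the scatter), so with the amide-type nitrogen methylated in both, the ring on this saturated chain carbon clearly matters. Replacing (4-chlorobenzyl)amino with (3,4-difluorobenzyl)(methyl)amino on the carbonyl carbon gives a 1.2-fold lower number from compound 1 to compound 3 (0.07 log units; within the scatter), so a low number does not depend on the amide hydrogen when this ring is present. Nothing available explains the effect of the ring change. The compounds shown do not separate the effect of the methyl group from that of the ring, and they leave open how an unsubstituted phenyl or a 4-methoxyphenyl would behave here.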